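The compounds below may be only part of what the source reports. "The series", "measured", "known", "first", "only" and "open" are said of these compounds alone.

Three compounds share one core and differ only in the group attached to the carbonyl carbon of the amide. Compound 1 `CCC(=O)N(Cc1ccc(OC)c(O)c1)c1cc(OC)c(OC)c(OC)c1` gives 61 nM in a functional assay on HCT-116 cells (Homo sapiens) for inhibition, read by MTT assay, with a stated time of 48 h; on this read-out higher numbers stand for weaker inhibition and lower numbers for stronger inhibition. Compound 2 `COc1ccc(CN(C(=O)C2CC2)c2cc(OC)c(OC)c(OC)c2)cc1O` gives 49 nM in this assay. Compound 3 `COc1ccc(CN(C(=O)CCCCCl)c2cc(OC)c(OC)c(OC)c2)cc1O` gives 220 nM in this assay, the highest of the three numbers, which makes it the weakest inhibitor of the set; the steps of a 3.6-fold higher number from compound 1 to compound 3 (0.56 log units; beyond the scatter) and a 4.5-fold higher number from compound 2 to compound 3 (0.65 log units; beyond the scatter) both lie beyond the scatter. Compound 4 `C=CC(=O)N(Cc1ccc(OC)c(O)c1)c1cc(OC)c(OC)c(OC)c1` has not yet been measured. Its difference from compound 3 is vinyl in place of 4-chlorobutyl on a carbonyl carbon. The two measured steps into compound 3 bear directly on this change: each put 4-chlorobutyl on the carbonyl carbon in place of a group of few heavy atoms, and each raised the number beyond the scatter. Vinyl, with its two heavy atoms, returns to that smaller size, so compound 4 is expected to move back toward the numbers of compound 1 and compound 2, with an expected step of a 4.0-fold lower number from compound 3 to compound 4 (0.60 log units; beyond the scatter). Compound 4 is therefore estimated at 55 nM, with a likely range from 25 nM to 130 nM.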

Compound 4, half-maximal inhibitory concentration: 98 nM
The estimate for compound 4 lay 1.8-fold (0.25 log units) below the measured number, and the stated range covers the measured number.
By their numbers in this assay, from the lowest: compounds 2, 1 and 4 (each within the scatter of the next); then compound 3.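

In this assay, vinyl in place of 4-chlorobutyl on the carbonyl carbon gives a 2.2-fold lower number from compound 3 to compound 4 (0.35 log units; beyond the scatter) and so shows that the higher number of compound 3 does not persist once the 4-chlorobutyl group is gone. Vinyl then sits level with the two other small groups, with a 2.0-fold higher number from compound 2 to compound 4 (0.30 log units; within the scatter) and a 1.6-fold higher number from compound 1 to compound 4 (0.21 log units; within the scatter) both within the scatter, so this assay does not separate ethyl, cyclopropyl and vinyl at this position. Nothing measured here explains why 4-chlorobutyl stands apart from these three groups.

The compounds shown leave open whether the higher number of compound 3 goes with the length of the chain or with its chlorine, a question that a plain butyl chain would help to settle. They also leave open how an amine or a carboxylic acid carried on this carbonyl carbon would read.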